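Benzamide series: chloro for methoxy, all values at the limit

The compounds below may be only part of what the source reports. "The series", "measured", "known", "first", "only" and "open" are said of these compounds alone.

Compound 1 `Nc1ccccc1NC(=O)CCCNCC(=O)Nc1ccc(Cl)cc1`, compound 2 `COc1ccc(NC(=O)CNc2ccc(C(=O)Nc3ccccc3N)cc2)cc1` and compound 3 `COc1ccc(NC(=O)CNCCCC(=O)Nc2ccccc2N)cc1` have been run in a functional assay on HCT-116 cells (Homo sapiens) for inhibition, read by MTT assay, with a stated time of 2 days; on this read-out lower numbers stand for higher toxicity in this test and higher numbers for lower toxicity in this test. In this assay compound 1 gives only a limit, > 100000 nM. Compound 2 likewise gives only a limit in this assay, > 100000 nM. Compound 3 also returns a limit in this assay, > 100000 nM. The three results are summed up by the limit of > 100000 nM in this assay, at which 3 of the 3 values shown sit. Compound 3 and compound 1 differ in one place, (chloro in place of methoxy on an aromatic carbon), and the step from compound 3 to compound 1 in this assay, a step that the two limits leave unreadable from compound 3 to compound 1, is left unreadable by the two limits. Compound 2 and compound 3 differ in more than one place; the difference between the two cores is not broken down here.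

Compound 4 `Nc1ccccc1NC(=O)c1ccc(NCC(=O)Nc2ccc(Cl)cc2)cc1` has not yet been measured in this assay. Among the compounds with values here, it differs from compound 2 by chloro in place of methoxy on an aromatic carbon, the same change as the one from compound 3 to compound 1, at a place described in the same words. The earlier step gives no measured size to carry over. What can be expected rests on compound 2 sitting at a limit in this assay, > 100000 nM. It rests further on all three values sitting together at the limit of > 100000 nM in this assay, at which 3 of the 3 values shown sit. Compound 4 is therefore expected to stay near that limit, the expected step being a step that the limit leaves unreadable from compound 2 to compound 4. The estimate for compound 4 in this assay is 150000 nM, with a range from 40000 nM to 600000 nM.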

Compound 4, concentration lethal to 50% of the cells: > 100000 nM
Compound 4: only a limit was reported; the forecaster's own chance of this, stated with the estimate: 85%; the middle value lies beyond the limit too.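

In this assay compound 4 gives only a limit, > 100000 nM. Compound 2 also sits at a limit, so no step can be read from compound 2 to compound 4, and the chloro for methoxy change stays unsized in this pair as well. All values shown sit together: the limit of > 100000 nM in this assay, at which 4 of the 4 values shown sit. The compounds shown leave open whether chloro and methoxy differ at all in this assay.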